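A Ketone Aryl Swap in a Chalcone-Like Series

The source may report more compounds than this note shows. Statements on the series, on what has been measured and on what is new or still open speak of the compounds shown alone.

Measured compounds:
- compound 1, `COc1ccc(C(=O)/C=C/c2cc(-c3cc(OC)c(OC)c(OC)c3)n3nc(-c4ccccc4)cc3n2)cc1`: 13200 nM
- compound 2, `COc1ccc(-c2cc(/C=C/C(=O)c3cc(OC)c(OC)c(OC)c3)nc3cc(-c4ccccc4)nn23)cc1OC`: 4700 nM

In a functional assay on MDA-MB-231 cells (Homo sapiens) for antiproliferative activity, read by MTT assay, with a stated time of 24 h (a higher number here means a weaker inhibitor, a lower number a stronger inhibitor), compound 2 gives 4700 nM, the lower of the two numbers on hand. Going by the values given here, compound 1 gives 13200 nM in this assay, a gap beyond the usual scatter, and the two structures differ in more than one place, so no single step between them can be read.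

Compound 3, `COc1ccc(-c2cc(/C=C/C(=O)c3ccc(C)cc3)nc3cc(-c4ccccc4)nn23)cc1OC`, has not yet been measured. It differs from compound 2 by 4-methylphenyl in place of 3,4,5-trimethoxyphenyl on a carbonyl carbon. Among the compounds with values here, no measured pair isolates this change, so the expected step rests on no direct precedent. The trimethoxyphenyl that leaves is the group carried on the carbonyl in the stronger of the two measured compounds; its loss is expected to weaken inhibition, with the step from compound 2 to compound 3 estimated at a 2.6-fold higher number from compound 2 to compound 3 (0.41 log units; beyond the scatter). Compound 3 is expected to give about 12000 nM in this assay, within a range from 4000 nM to 40000 nM.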

Compound 3, half-maximal inhibitory concentration: 19800 nM
Compound 3: the middle estimate sits 1.7-fold (0.22 log units) below what was measured; measured number inside the range.
By their numbers in this assay, from the lowest: compound 2; then compounds 1 and 3 (each within the scatter of the next).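

A single swap in this series now has a measured size: a 4.2-fold higher number from compound 2 to compound 3 (0.62 log units; beyond the scatter) in this assay. With the rest of the molecule unchanged, 4-methylphenyl in place of 3,4,5-trimethoxyphenyl on a carbonyl carbon weakens inhibition, showing that the aryl group at this position affects the read-out, something compounds 1 and 2 could not show, as they differ in more than one place. No measurement at hand speaks to the reason for this step.

From the compounds shown here alone, it remains open whether the difference follows the loss of the methoxy groups or the arrival of the methyl group, and how an unsubstituted phenyl, a 4-chlorophenyl or a phenyl bearing an amine would read on this carbonyl carbon. Whether the same swap would give a similar step with other groups on the shared core is also unknown.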